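Methoxy for nitro, repeated on a chloro-bearing core

The compounds below may be only part of what the source reports. "The series", "measured", "known", "first", "only" and "open" are said of these compounds alone.

In a functional assay on CHO cells for agonist activity at adenosine receptor A1 (Homo sapiens), read by fluorescence and ERK phosphorylation, with stated times of 30 min and 1.5 h, tested at 10 uM (on this read-out higher numbers stand for a stronger effect at the one concentration tested and lower numbers for a weaker effect), compound 1 `Nc1scc(-c2cccc([N+](=O)[O-])c2)c1C(=O)c1ccccc1` gives 50%. Compound 2 `COc1cccc(-c2csc(N)c2C(=O)c2ccccc2)c1` differs from compound 1 by methoxy in place of nitro on an aromatic carbon; in this assay compound 2 gives 34%, so that change made the step of a number 16 percentage points lower from compound 1 to compound 2 (beyond the scatter). Compound 3 `Nc1scc(-c2cccc([N+](=O)[O-])c2)c1C(=O)c1ccc(Cl)cc1` stands on a second core, differing from compound 1 by chloro in place of hydrogen on an aromatic carbon; in this assay compound 3 gives 42%, the step being a number 8 percentage points lower from compound 1 to compound 3 (within the scatter), and the two numbers cannot be ordered. Compound 4 `COc1cccc(-c2csc(N)c2C(=O)c2ccc(Cl)cc2)c1` is not yet measured. It differs from compound 3 by methoxy in place of nitro on an aromatic carbon, which is the same change as that between compound 1 and compound 2, at the same place, now carried out on the core of compound 3. Among the compounds shown this change occurs twice in all, and only once with numbers on both sides. For compound 4 the expected step is a number 16 percentage points lower from compound 3 to compound 4 (beyond the scatter), because the same change gave a number 16 percentage points lower from compound 1 to compound 2 (beyond the scatter). That rests on one measured instance, and on the single concentration read-out. The estimate for compound 4 in this assay is 26%, with a range from 12% to 40%.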

Compound 4, a percentage reported as activity, at one concentration (the size of the read-out at that concentration, not a potency): 60%
Beside the measured number, compound 4's estimate is 34 percentage points below it; measured number above the stated range.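

In this assay, methoxy in place of nitro on the core of compound 3 gave a number 18 percentage points higher from compound 3 to compound 4 (beyond the scatter), so the change does not carry its direction from one core to the other: the same change on two cores in this assay, a number 16 percentage points lower (beyond the scatter) from compound 1 to compound 2 and a number 18 percentage points higher (beyond the scatter) from compound 3 to compound 4, 34 percentage points apart, beyond the scatter of two such steps
Read the other way round, chloro in place of hydrogen with methoxy present gave a number 26 percentage points higher from compound 2 to compound 4 (beyond the scatter), so within these four compounds the effect of either change depends on the other, and the two do not simply add: the same change on two cores in this assay, a number 8 percentage points lower (within the scatter) from compound 1 to compound 3 and a number 26 percentage points higher (beyond the scatter) from compound 2 to compound 4, 34 percentage points apart, beyond the scatter of two such steps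
This rests on one pair per core at a single concentration; it shows that a step measured on the core of compound 1 was a poor guide on the chloro-bearing core, but it does not explain the reversal or show that it would hold as a difference in potency.

The compounds shown carry only two groups at each of the two places that vary. From the compounds shown here alone, it remains open whether fluoro or methyl in place of chloro, or an amine or a carboxylic acid in place of nitro, would follow the pattern of the core of compound 1 or that of compound 3.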